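Trading 4-hydroxyphenyl for 3-nitrophenyl in a cytotoxic series

A few compounds are considered here, and "the series" means these few. Any claim that something is new, unique, unknown or untested is made for them only; others in the source may bear on it.

Compound 1 `C/C(=N\NC(=O)/C(C#N)=C/c1ccccc1)c1c(O)c2ccc(O)cc2oc1=O` gives 14800 nM 
Compound 2 `C/C(=N\NC(=O)/C(C#N)=C/c1ccc(O)cc1)c1c(O)c2ccc(O)cc2oc1=O` gives 6230 nM 
Compound 3 `C/C(=N\NC(=O)/C(C#N)=C/c1ccc(Br)cc1)c1c(O)c2ccc(O)cc2oc1=O` gives 11400 nM 

These three compounds were tested in a functional assay on A549 cells (Homo sapiens) for cytotoxicity, read by MTT assay, with a stated time of 24 h (a lower number here means a stronger inhibitor, a higher number a weaker inhibitor), and differ in one place only. Compound 2 stands at the low end of the numbers. The measurements show a 2.4-fold lower number from compound 1 to compound 2 (0.38 log units; beyond the scatter) when a hydroxy group replaces hydrogen on the aromatic ring. They also show a 1.8-fold higher number from compound 2 to compound 3 (0.26 log units; within the scatter) when bromo replaces that hydroxy group, and a 1.3-fold lower number from compound 1 to compound 3 (0.11 log units; within the scatter) when bromo replaces hydrogen.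

Compound 4 `C/C(=N\NC(=O)/C(C#N)=C/c1cccc([N+](=O)[O-])c1)c1c(O)c2ccc(O)cc2oc1=O` has 3-nitrophenyl in place of 4-hydroxyphenyl on a double-bonded chain carbon bound to a double-bonded chain carbon. Within the data shown here, no compound with a nitro group has been measured, so the steps above are only a rough guide. Losing the hydroxy group could undo some of the only step beyond the scatter, which is a 2.4-fold lower number from compound 1 to compound 2 (0.38 log units; beyond the scatter) for gaining it. The expected change in this assay is therefore small, close to the scatter and towards a higher number, an estimated 1.6-fold higher number from compound 2 to compound 4 (0.21 log units; within the scatter) for this swap. The estimate for compound 4 is 10000 nM (expected range 5000 nM to 20000 nM).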

Compound 4, half-maximal inhibitory concentration: 21900 nM
Compound 4: the middle estimate sits 2.2-fold (0.34 log units) below what was measured; the measured number lies above the stated range.
By their numbers in this assay, from the lowest: compounds 2, 3, 1 and 4 (each within the scatter of the next, the first and the last beyond it).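

In this assay, moving from 4-hydroxyphenyl to 3-nitrophenyl gives a 3.5-fold higher number from compound 2 to compound 4 (0.55 log units; beyond the scatter), so this aryl group on a double-bonded chain carbon can shift the number beyond the scatter in the unfavourable direction as well as the favourable one. The nitro group does not separate compound 4 from the other two, with a 1.5-fold higher number from compound 1 to compound 4 (0.17 log units; within the scatter) and a 1.9-fold higher number from compound 3 to compound 4 (0.28 log units; within the scatter), so among these substituents only compound 2 stands clearly apart from compound 4. No measured data on the compounds offer an explanation for this difference.

As far as these compounds go, how an amine or a carboxylic acid on the same phenyl ring would compare remains open, and so does whether the lower number of compound 2 is particular to hydroxy. It is also unknown whether a nitro group elsewhere on that ring would give a similar number.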